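The compounds below may be only part of what the source reports. "The series", "measured", "known", "first", "only" and "open" are said of these compounds alone.

Compound 1 `Cc1ccccc1C1CC(c2ccc(OCc3ccccc3)cc2)=NN1c1ccc(S(N)(=O)=O)cc1` gives >= 100000 nM in an ADME assay on MT4 cells (Homo sapiens) for cytotoxicity, read by MTT assay, with a stated time of 96 h (a higher number here means that more compound is tolerated, a lower number that less compound is tolerated), and this is a limit of the assay, not a number. Within the data shown here, compound 2 `NS(=O)(=O)c1ccc(N2N=C(c3ccc(OCc4ccccc4)cc3)CC2c2ccc(Cl)cc2)cc1` gives 70000 nM in this assay, which makes it the only true number so far.

The next compound keeps the shared core and alters a single spot. Compound 3 `Cc1ccc(C2CC(c3ccc(OCc4ccccc4)cc3)=NN2c2ccc(S(N)(=O)=O)cc2)cc1` has methyl in place of chloro on an aromatic carbon, para to a large group: methyl in place of chloro on an aromatic carbon. Cut one bond further out, the change reads 4-chlorophenyl to 4-methylphenyl.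

Among the measured compounds shown here, only one measured step bears on this, and it touches the same ring carbon substituent. That step is an at least 1.4-fold lower number from compound 1 to compound 2 (0.15 log units; that floor lies within the scatter), and it puts 4-chlorophenyl in place of 2-methylphenyl. It does not show that swapping this aryl group moves the number much, so no step beyond the usual scatter is expected in this assay. Compound 3 could also be expected to end at the limit of >= 100000 nM in this assay, at which 1 of the 2 values shown sits, giving no number at all.

The expected step is a 1.1-fold higher number from compound 2 to compound 3 (0.06 log units; within the scatter). For compound 3 the estimated value is 80000 nM, with an expected range from 40000 nM to 150000 nM.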

Compound 3, half-maximal cytotoxic concentration: 35000 nM
Beside the measured number, compound 3's estimate is 2.3-fold (0.36 log units) above it, outside the stated range (below it).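

Methyl in place of chloro on this aromatic carbon gives a 2.0-fold lower number from compound 2 to compound 3 (0.30 log units; within the scatter), so in this assay this swap does not separate the two compounds, and chloro and methyl cannot be told apart here. Among these compounds, the clearer signal comes from the methyl group's place on the phenyl ring: 4-methylphenyl in place of 2-methylphenyl gives an at least 2.8-fold lower number from compound 1 to compound 3 (0.45 log units; beyond the scatter), the first step in this small set to pass the scatter, whereas the step to the 4-chlorophenyl compound did not. That size is only a floor, since compound 1 stands at a limit of the assay and not at a true number: the limit of >= 100000 nM in this assay, at which 1 of the 3 values shown sits.

The compounds shown leave open whether a quite different group on this phenyl ring, such as an amine, a carboxylic acid or a longer chain, would move the number beyond the scatter. They also leave open how far compound 1 truly lies from compound 3, and whether the gain in sensitivity of the cells to the compound would hold for other groups placed as the methyl of compound 1 is.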